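Amide aryl swap in a low-toxicity series

The compounds below may be only part of what the source reports. "The series", "measured", "known", "first", "only" and "open" are said of these compounds alone.

The series is read in an ADME assay on Huh-7 cells (Homo sapiens) for cytotoxicity, with a stated time of 3 days; on this read-out higher numbers stand for lower toxicity in this test and lower numbers for higher toxicity in this test. Compound 1 `O=C(Nc1cccc(C(F)(F)F)c1)c1c(NO)cc(-c2cccs2)oc1=O` gives 11000 nM in this assay, and compound 2 `O=C(Nc1ccc(Cl)cc1)c1c(NCCO)cc(-c2cccc(Br)c2)oc1=O` gives 17000 nM. For compound 3 `O=C(Nc1ccc(Cl)cc1)c1c(NCCO)cc(-c2ccc(Br)cc2)oc1=O` this assay reports only a limit, > 20000 nM. Compound 3 thus stands at the limit of > 20000 nM in this assay, at which 1 of the 3 values shown sits. Within the data shown here, the single measured step, an at least 1.1-fold higher number from compound 2 to compound 3 (0.07 log units; that floor lies within the scatter), concerns the bromophenyl ring and does not touch the amide aryl group. Compound 4 `COc1cccc(NC(=O)c2c(NCCO)cc(-c3ccc(Br)cc3)oc2=O)c1` differs from compound 3 by 3-methoxyphenyl in place of 4-chlorophenyl on an amide-type nitrogen. Among the measured compounds shown here, no measured step bears on this change. Compound 1 and compound 2 carry other amide aryl groups and also sit in the low-toxicity region of this assay. No step beyond the scatter is therefore expected in this assay. The estimated step is a number no higher from compound 3 to compound 4 (the limit leaves the size open). Compound 4 is expected to give about 20000 nM, within 9000 nM to 45000 nM, with another limit value likely.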

Compound 4, half-maximal cytotoxic concentration: > 20000 nM
Compound 4: no number, only a limit; the forecaster's own chance of this, stated with the estimate: 60%; the middle value lies on the limit itself.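

Compound 3 and compound 4 each give only a limit in this assay, so no step between them can be read: the limit of > 20000 nM in this assay, at which 2 of the 4 values shown sit.

The compounds shown leave open whether 3-methoxyphenyl in place of 4-chlorophenyl changes the read-out at all.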